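The compounds below may be only part of what the source reports. "The series", "measured", "known", "first", "only" and "open" are said of these compounds alone.

In a functional assay on HepG2 cells (Homo sapiens) for antiproliferative activity, read by CCK-8 assay, with a stated time of 48 h (a lower number here means a stronger inhibitor, a higher number a weaker inhibitor), compound 1 `COc1ccc(/C=C\c2cc(OC)c(OC)c(OC)c2)cc1OCc1ccc(CN2CCCC[C@H]2C(=O)O)cc1` stands at > 10000 nM, which is a limit of the assay and not a number. Compound 2 `COc1ccc(/C=C\c2cc(OC)c(OC)c(OC)c2)cc1OCc1ccc(CN2CCCCC2C(=O)O)cc1` gives 3100 nM. Among the measured compounds shown here, the only measured step, an at least 3.2-fold lower number from compound 1 to compound 2 (0.50 log units; beyond the scatter), lies beyond the scatter and reflects (the fact that one of compounds 1 and 2 is drawn with a defined configuration and the other without, at the place where they differ). Compound 3 `COc1ccc(/C=C\c2cc(OC)c(OC)c(OC)c2)cc1OCc1ccc(CN2CC[C@H](O)C2)cc1` carries a new group on the core of compound 1: 3-hydroxypyrrolidin-1-yl in place of 2-carboxypiperidin-1-yl on a saturated chain carbon bound to an aromatic carbon. For the measured compounds named here, no measured step covers this exchange, so the size of an at least 3.2-fold lower number from compound 1 to compound 2 (0.50 log units; beyond the scatter) serves only as a loose guide. The expected step is an at least 4.0-fold lower number from compound 1 to compound 3 (0.60 log units; beyond the scatter), towards a lower number in this assay. For compound 3 the estimated value is 2500 nM, with an expected range of 400 nM to 10000 nM.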

Compound 3, half-maximal inhibitory concentration: 6600 nM
Estimate against measurement, compound 3: 2.6-fold (0.42 log units) below, within the range that was stated.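

In this assay, 3-hydroxypyrrolidin-1-yl in place of 2-carboxypiperidin-1-yl on a saturated chain carbon bound to an aromatic carbon gives a 2.1-fold higher number from compound 2 to compound 3 (0.33 log units; beyond the scatter). This modest step changes the ring and its substituent together, and compound 2 carries no drawn configuration at the ring carbon. Compound 1 stands at > 10000 nM, a limit of the assay and not a number. The same exchange, read against that limit, gives an at least 1.5-fold lower number from compound 1 to compound 3 (0.18 log units; that floor lies within the scatter).

Open, as far as these compounds go, is whether ring size or substituent carries the difference. Plain piperidin-1-yl, without the carboxylic acid or hydroxyl, would separate the two.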